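Replacing a benzyl amide with a pyrazinyl amide

The compounds below may be only part of what the source reports. "The series", "measured", "known", "first", "only" and "open" are said of these compounds alone.

Measured so far in a functional assay on the whole organism for inhibition, with Rattus norvegicus as the target, read by paw edema, at a dose of 100 mg/kg by the oral route; a higher number here means more inhibition at the dose given (going by the name of the read-out), a lower number less inhibition:
compound 1 `CCCCNC(=O)c1c(O)c2cccnc2n(-c2ccccc2)c1=O` gives 12.8%
compound 2 `O=C(NCc1ccccc1)c1c(O)c2cccnc2n(-c2ccccc2)c1=O` gives 1.6%
compound 3 `Cc1ccccc1NC(=O)c1c(O)c2cccnc2n(-c2ccccc2)c1=O` gives 11.7%

Compound 2 stands lowest of the three numbers; compound 3 lies closer to it and compound 1 further away, both beyond the scatter. Compound 4 `O=C(Nc1cnccn1)c1c(O)c2cccnc2n(-c2ccccc2)c1=O` differs from compound 2 only on the amide nitrogen: pyrazin-2-yl in place of benzyl on an amide-type nitrogen. Going by the values given here, two measured steps bear on this. Going from a chain-bound group to an aryl group on that nitrogen gave a number 10.1 percentage points higher from compound 2 to compound 3 (beyond the scatter), whereas going the other way gave a number 11.2 percentage points lower from compound 1 to compound 2 (beyond the scatter). Compound 4 again carries an aromatic ring directly on the amide nitrogen, so a modest upward step is expected, a number 7.4 percentage points higher from compound 2 to compound 4 (within the scatter). Compound 4 is therefore estimated at 9%, within 0% to 22%.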

Compound 4, a percentage reported as inhibition, in the whole organism at one dose (the size of the read-out at that dose, not a potency): 29.6%
Estimate against measurement, compound 4: 20.6 percentage points below, outside the stated range (above it).
By their numbers in this assay, from the lowest: compound 2; then compounds 3 and 1 (each within the scatter of the next); then compound 4.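

Pyrazin-2-yl on the amide nitrogen raises the number above all three earlier groups: benzyl (a number 28 percentage points higher from compound 2 to compound 4 (beyond the scatter)), 2-methylphenyl (a number 17.9 percentage points higher from compound 3 to compound 4 (beyond the scatter)) and butyl (a number 16.8 percentage points higher from compound 1 to compound 4 (beyond the scatter)). An aromatic ring directly on that nitrogen is thus not enough on its own, since compound 3 also carries one and stays well short of compound 4. Nothing measured here accounts for the rise. The compounds shown leave open whether the two ring nitrogens of pyrazin-2-yl matter, which pyridin-2-yl or unsubstituted phenyl on the amide nitrogen would help to settle.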